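Adding fluoro to the pyridin-3-yl group of compound 3

The source may hold more compounds than are shown below. What is called first, only, known or untested is meant among the compounds shown, and "the series" means these compounds.

Values in an ADME assay (liver) for metabolic stability, with Liver microsome (Rattus norvegicus) as the target, using microsomes and NADPH, with a stated time of 30 min, tested at 1 uM (a higher number here means faster removal of the compound, a lower number slower removal), so far
compound 1 `Nc1ccc(S(=O)(=O)N2CCN(c3ncc(C(O)(C(F)(F)F)C(F)(F)F)cc3-c3ccoc3)CC2)cn1`: 57 mL.min-1.g-1
compound 2 `Nc1ccc(S(=O)(=O)N2CCN(c3ncc(C(O)(C(F)(F)F)C(F)(F)F)cc3-c3ccccc3O)CC2)cn1`: 125 mL.min-1.g-1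
compound 3 `Nc1ccc(S(=O)(=O)N2CCN(c3ncc(C(O)(C(F)(F)F)C(F)(F)F)cc3-c3cccnc3)CC2)cn1`: 20 mL.min-1.g-1

Compound 3 carries the lowest of the three numbers, and both gaps to it lie beyond the scatter. Compound 4 `Nc1ccc(S(=O)(=O)N2CCN(c3ncc(C(O)(C(F)(F)F)C(F)(F)F)cc3-c3cncc(F)c3)CC2)cn1` differs from it by pyridin-3-yl to 5-fluoropyridin-3-yl, that is fluoro in place of hydrogen on an aromatic carbon with fluoro in place of hydrogen on an aromatic carbon. Within the data shown here, no measured step makes this change. The nearest evidence is a 2.9-fold lower number from compound 1 to compound 3 (0.45 log units; beyond the scatter) and a 6.3-fold lower number from compound 2 to compound 3 (0.80 log units; beyond the scatter) as modest steps, each replacing an entire group rather than one hydrogen. The number in this assay is therefore expected to move no further than the scatter, in no firm direction. The estimated change is a 1.2-fold higher number from compound 3 to compound 4 (0.08 log units; within the scatter) and nothing larger is expected. For compound 4 the estimate is 24 mL.min-1.g-1 within an expected range from 12 mL.min-1.g-1 to 48 mL.min-1.g-1 in this read-out.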

Compound 4, intrinsic clearance in microsomes: 19 mL.min-1.g-1
Compound 4: the middle estimate sits 1.3-fold (0.10 log units) above what was measured, and the stated range covers the measured number.
By their numbers in this assay, from the lowest: compounds 4 and 3 (each within the scatter of the next); then compound 1; then compound 2.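

In this assay, fluoro in place of hydrogen on the pyridin-3-yl group, two atoms from the ring nitrogen, gives a 1.1-fold lower number from compound 3 to compound 4 (0.02 log units; within the scatter), so this one-atom change leaves the number within the scatter. The larger gaps remain with 5-fluoropyridin-3-yl in place of the other groups: a 6.6-fold lower number from compound 2 to compound 4 (0.82 log units; beyond the scatter) and a 3.0-fold lower number from compound 1 to compound 4 (0.48 log units; beyond the scatter). Nothing available gives a reason for the absence of a shift at this position. Open, going by these compounds, is whether a methoxy group or an amine at this same ring carbon would shift the number, and whether fluoro on another ring carbon would behave in the same way.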